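A few compounds are considered here, and "the series" means these few. Any claim that something is new, unique, unknown or untested is made for them only; others in the source may bear on it.

Measured so far in an assay on cells for displacement of a labelled ligand from Glucagon receptor (Homo sapiens), in the presence of a further agent that is not named here; a lower number here means a stronger inhibitor, a higher number a weaker inhibitor:
compound 1, `CCCC(Nc1ccc(-n2cc(C(F)(F)F)cn2)nc1)c1ccc(C(=O)NCCC(=O)O)cc1`, gives 170 nM
compound 2, `O=C(O)CCNC(=O)c1ccc(C(Oc2ccc(-n3cc(C(F)(F)F)cn3)cc2)C2CC2)cc1`, gives 1300 nM
compound 3, `O=C(O)CCNC(=O)c1ccc(C(Oc2ccc(-n3cc(C(F)(F)F)cn3)cc2)C2CCC2)cc1`, gives 700 nM

Compound 3 holds the second highest of the three numbers. Its nearest neighbour is compound 2, whose number is higher but within the scatter. Compound 1 has the lowest number, beyond the scatter from compound 3; compound 1 differs from compound 3 in more than one place, so those two values alone do not isolate any single change.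

Compound 4 is `CCC(Oc1ccc(-n2cc(C(F)(F)F)cn2)cc1)c1ccc(C(=O)NCCC(=O)O)cc1`. Against compound 3 it carries ethyl in place of cyclobutyl on a saturated chain carbon bound to an aromatic carbon and an oxygen on an aromatic ring. Among the compounds with values here, the only measured step at the same place is a 1.9-fold lower number from compound 2 to compound 3 (0.27 log units; within the scatter), which did not move the number beyond the scatter. That step and the present one each exchange one small saturated carbon group for another at the same carbon, and there is nothing else to suggest a larger effect here. No step beyond the scatter is therefore expected in this assay, in either direction.

Compound 4 is accordingly estimated at 800 nM, with a range of 350 nM to 1800 nM. The expected step, a 1.1-fold higher number from compound 3 to compound 4 (0.06 log units; within the scatter), is one that would stay within the scatter.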

Compound 4, inhibition constant: 1400 nM
Estimate against measurement, compound 4: 1.8-fold (0.24 log units) below, within the range that was stated.
By their numbers in this assay, from the lowest: compound 1; then compounds 3, 2 and 4 (each within the scatter of the next).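

In this assay, the open-chain ethyl group gives a 2.0-fold higher number from compound 3 to compound 4 (0.30 log units; within the scatter) and, against the smaller ring, a 1.1-fold higher number from compound 2 to compound 4 (0.03 log units; within the scatter). With a 1.9-fold lower number from compound 2 to compound 3 (0.27 log units; within the scatter) already known, cyclopropyl, cyclobutyl and ethyl now all lie within the scatter of one another on this saturated chain carbon, so neither the four-membered ring, the three-membered ring nor the absence of a ring separates these compounds in this assay. No measurement available here bears on why these three groups read alike.

Going by these compounds, whether cyclohexyl, a hydroxyl group or an amine on this carbon would take the number beyond the scatter remains open. Also open, on these data alone, is which of its several differences from the other compounds goes with the value of compound 1, 170 nM.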